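Ethyl in Place of Cyclopentylcarbonyl on the Ring Amine

This account rests on a few compounds, and the source may have more. Where it says the series, first, only, none or still open, it means among the compounds named here.

Measured compounds:
compound 1, `CCN1CCN(CCCn2cnc3c(N4CCN(CC)CC4)nc(NCc4ccccc4)nc32)CC1`: 140 nM
compound 2, `CCN1CCN(CCCn2cnc3c(N4CCN(C(=O)C5CCCC5)CC4)nc(NCc4ccc(N(CC)CC)cc4)nc32)CC1`: 8800 nM

Going by the values given here, in an assay on HEK293 cells for antagonist activity at Toll-like receptor 9 (Homo sapiens), read by spectrophotometry (on this read-out higher numbers stand for weaker inhibition and lower numbers for stronger inhibition), compound 2 gives 8800 nM, the highest of the two numbers recorded, while the only other measured compound, compound 1, gives 140 nM; this gap lies beyond the usual scatter. Among the compounds with values here, compound 1 and compound 2 differ in two places at once, so no single step between them is known. Compound 3, `CCN1CCN(CCCn2cnc3c(N4CCN(CC)CC4)nc(NCc4ccc(N(CC)CC)cc4)nc32)CC1`, keeps compound 2 unchanged but for one place: ethyl in place of cyclopentylcarbonyl on an amine nitrogen in a ring. Compound 3 thus carries the ring amine substituent of compound 1 together with the benzyl substituent of compound 2. Which of the two changes between compound 1 and compound 2 accounts for the gap cannot be told from these numbers. For this reason the step of a 9.8-fold lower number from compound 2 to compound 3 (0.99 log units; beyond the scatter) is expected to lower the number, probably beyond the scatter, yet leave compound 3 well short of compound 1. For compound 3 the estimate is 900 nM, with a range from 150 nM to 5000 nM.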

Compound 3, half-maximal inhibitory concentration: 440 nM
The estimate for compound 3 lay 2.0-fold (0.31 log units) above the measured number; the range from low to high includes it.
By their numbers in this assay, from the lowest: compound 1; then compound 3; then compound 2.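

In this assay, putting ethyl in place of cyclopentylcarbonyl on the ring amine gives a 20-fold lower number from compound 2 to compound 3 (1.30 log units; beyond the scatter), so this position alone has a large effect on the number. The other change, diethylamino in place of hydrogen on an aromatic carbon, gives a 3.1-fold higher number from compound 1 to compound 3 (0.50 log units; beyond the scatter), a modest step, so the two changes that were tangled together in the first two compounds can now be read apart, and the ring amine step is the larger of them. Nothing shown here explains why either change moves the number as it does. From the compounds shown here alone, whether acetyl or cyclopentyl on the same ring nitrogen would behave like ethyl or like cyclopentylcarbonyl stays open, so the carbonyl and the carbon ring cannot yet be separated. Also open, going by these compounds, is how dimethylamino would compare with diethylamino on the aromatic carbon.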